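The compounds below may be only part of what the source reports. "The series", "measured", "known", "first", "only" and "open" are said of these compounds alone.

Of the compounds shown here, two of a shared core have been measured. Compound 1 `Cc1c(Nc2ccc(S(C)(=O)=O)cc2F)ncnc1O[C@H]1CC[C@]2(CC1)COC(C)(C)C2` carries a fluoro group on its aromatic ring, while compound 2 `Cc1c(Nc2ccc(S(C)(=O)=O)cc2)ncnc1O[C@H]1CC[C@]2(CC1)COC(C)(C)C2` has a hydrogen at that position instead. In a functional assay on HEK293 cells with Glucose-dependent insulinotropic receptor (Homo sapiens) as the target, read by HTRF and cAMP accumulation, with a stated time of 30 min (a higher number here means a larger maximal response, a lower number a smaller maximal response), compound 1 gives 91%, and compound 2 gives 92%. The single step of a number 1 percentage points higher from compound 1 to compound 2 (within the scatter) connects them, and since it lies within the usual scatter, compound 1 stands level with compound 2 on the numbers shown: the two are best read as equal.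

The next compound, compound 3 `CCc1c(Nc2ccc(S(C)(=O)=O)cc2F)ncnc1O[C@H]1CC[C@]2(CC1)COC(C)(C)C2`, differs from compound 1 in one place: methyl in place of hydrogen on a saturated chain carbon bound to an aromatic carbon. Going by the values given here, no measured step concerns a change of this kind, and the only measured step available, a number 1 percentage points higher from compound 1 to compound 2 (within the scatter), was itself within the scatter. Nothing in the data therefore points to a shift in this assay in either direction, and no step beyond the scatter is expected. Compound 3 is accordingly estimated to reach 90% in this assay, with a range from 75% to 102%, which amounts to an expected step of a number 1 percentage points lower from compound 1 to compound 3 (within the scatter).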

Compound 3, intrinsic activity: the largest response reached, in percent of the reference agonist's: 82%
Compound 3: the middle estimate sits 8 percentage points above what was measured; low and high end bracket the measured number.
By their numbers in this assay, from the lowest: compounds 3, 1 and 2 (each within the scatter of the next).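

The step from methyl to ethyl is the only one shown at this place in the shared core, as the earlier pair differed only by a fluoro on an aromatic carbon. Placing methyl in place of hydrogen on a saturated chain carbon bound to an aromatic carbon gives a number 9 percentage points lower from compound 1 to compound 3 (within the scatter) in this assay, so the two compounds are best read as equal, and this one added carbon leaves the maximal response intact within the usual scatter of repeated measurements. No measurement shown offers an explanation for the size of this step.

From the compounds shown here alone, whether the same place also keeps the maximal response with a longer chain such as propyl, or with an amine or a carboxylic acid at the end of the chain, stays open. Going by these compounds, it is equally open whether ethyl would give a similar result on the core of compound 2, where hydrogen stands in place of the fluoro, since a single step at one place cannot show how the two changes combine.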